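Dropping One Methoxy Group: From Compound 2 to Compound 4

The compounds below may be only part of what the source reports. "The series", "measured", "known", "first", "only" and "open" are said of these compounds alone.

Measured so far in a functional assay on Hs 683 cells (Homo sapiens) for inhibition, read by colorimetric assay and MTT assay, with a stated time of 72 h; on this read-out higher numbers stand for weaker inhibition and lower numbers for stronger inhibition:
- compound 1, `COc1cc(C(=O)NNC(=S)Nc2csc(-c3ccccc3)c2)cc(OC)c1OC`, for which compound 1 gives 42000 nM
- compound 2, `COc1cc(C(=O)NNC(=S)Nc2csc(-c3ccc(C)cc3)c2)cc(OC)c1OC`, for which compound 2 gives 42000 nM
- compound 3, `COc1cc(OC)cc(C(=O)NNC(=S)Nc2csc(-c3ccc(C)cc3)c2)c1`, for which compound 3 gives 37000 nM

Compound 2 sits level with compound 1 at the digits shown, and these two are together the highest of the three numbers. Its nearest neighbour is compound 1, with no change at the digits printed from compound 1 to compound 2 (within the scatter); its furthest is compound 3, with a 1.1-fold lower number from compound 2 to compound 3 (0.06 log units; within the scatter). All three numbers therefore lie within the usual scatter of one another.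

Compound 4, `COc1ccc(C(=O)NNC(=S)Nc2csc(-c3ccc(C)cc3)c2)cc1OC`, has not yet been measured. It differs from compound 2 in one place: hydrogen in place of methoxy on an aromatic carbon. Among the measured compounds shown here, the measured step closest in kind is the one from compound 2 to compound 3, which is also hydrogen in place of methoxy on an aromatic carbon, though not at the same carbon; that step was a 1.1-fold lower number from compound 2 to compound 3 (0.06 log units; within the scatter). The step of no change at the digits printed from compound 1 to compound 2 (within the scatter) likewise shows little movement. On this basis compound 4 is expected to show a 1.1-fold lower number from compound 2 to compound 4 (0.02 log units; within the scatter), no change beyond the scatter. The estimate for compound 4 is 40000 nM, with a range from 25000 nM to 65000 nM.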

Compound 4, half-maximal inhibitory concentration: 39000 nM
Estimate against measurement, compound 4: 1.0-fold (0.01 log units) above; low and high end bracket the measured number.
By their numbers in this assay, from the lowest: compounds 3, 4, 1 and 2 (each within the scatter of the next).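

In this assay, hydrogen in place of methoxy at this carbon, which is ortho to a methoxy group and meta to a large group, gives a 1.1-fold lower number from compound 2 to compound 4 (0.03 log units; within the scatter) and so does not separate the two compounds. The same exchange at a different carbon of the six-membered aromatic ring gave a 1.1-fold lower number from compound 2 to compound 3 (0.06 log units; within the scatter) and was also within the scatter, so losing either of these methoxy groups from compound 2 leaves the read-out within the scatter. Nothing measured here gives a reason for this result.

The compounds shown leave open whether a different group at this carbon, such as an amine or a carboxylic acid, would shift the number beyond the scatter. They also leave open what would happen if both of the remaining methoxy groups gave way to hydrogen.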